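This account rests on a few compounds, and the source may have more. Where it says the series, first, only, none or still open, it means among the compounds named here.

Three compounds share one core and differ only in the group on an aromatic carbon of the fused ring system. Compound 1 `C=CCNc1nc(NCc2ccc(C(=O)Nc3ccc(F)cc3)cc2)c2ccccc2n1` carries an allylamino group and gives 14000 nM in a functional assay on HCT-116 cells (Homo sapiens) for inhibition, read by luminescence and resazurin assay, with a stated time of 3 days; a higher number here means a weaker inhibitor, a lower number a stronger inhibitor. Compound 2 `CCCCNc1nc(NCc2ccc(C(=O)Nc3ccc(F)cc3)cc2)c2ccccc2n1` carries a butylamino group and gives 1400 nM in the same assay. Compound 3 `CN(C)c1nc(NCc2ccc(C(=O)Nc3ccc(F)cc3)cc2)c2ccccc2n1` carries a dimethylamino group and gives 1900 nM. Compound 3 therefore stands second of the three numbers: it sits close to compound 2, the two being within the scatter, while it lies well apart from compound 1, as the step of a 7.4-fold lower number from compound 1 to compound 3 (0.87 log units; beyond the scatter) shows.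

Compound 4 `O=C(Nc1ccc(F)cc1)c1ccc(CNc2nc(NC3CC3)nc3ccccc23)cc1` is the next compound; the change from compound 3 is cyclopropylamino in place of dimethylamino on an aromatic carbon. Within the data shown here, two measured steps bear on it. The step of a 10-fold lower number from compound 1 to compound 2 (1.00 log units; beyond the scatter) and the step of a 7.4-fold lower number from compound 1 to compound 3 (0.87 log units; beyond the scatter) show that the choice of group at this aromatic carbon can move the number substantially, whereas the step of a 1.4-fold higher number from compound 2 to compound 3 (0.13 log units; within the scatter) lies within the scatter. A cyclopropylamino group resembles neither the butylamino nor the dimethylamino group closely, so the direction is uncertain; the author expects a small loss in this assay for compound 4, with a 1.6-fold higher number from compound 3 to compound 4 (0.20 log units; within the scatter). Compound 4 is thus estimated at 3000 nM, with a range from 900 nM to 10000 nM.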

Compound 4, half-maximal inhibitory concentration: 2700 nM
Compound 4: middle estimate off by 1.1-fold (0.05 log units), on the high side; low and high end bracket the measured number.
By their numbers in this assay, from the lowest: compounds 2, 3 and 4 (each within the scatter of the next); then compound 1.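

In this assay, replacing dimethylamino, which has no ring and no hydrogen-bond donor, with cyclopropylamino, which has both, gives a 1.4-fold higher number from compound 3 to compound 4 (0.15 log units; within the scatter) on this aromatic carbon between two ring nitrogen atoms, and cyclopropyl in place of butyl on the nitrogen gives a 1.9-fold higher number from compound 2 to compound 4 (0.29 log units; within the scatter) and likewise stays within the scatter. Cyclopropyl in place of allyl gives a 5.2-fold lower number from compound 1 to compound 4 (0.71 log units; beyond the scatter) and lies beyond it, so compound 1 now stands apart from three compounds carrying different groups at this position. Nothing available accounts for that separation.

From the compounds shown here alone, whether a propylamino group, the closest chain to allylamino, would stay with compounds 2, 3 and 4 or fall with compound 1 remains open. The compounds shown also leave open how a plain amino group or a morpholine ring would behave here.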